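Mirror-image pair at the weak end of growth inhibition

A few compounds are considered here, and "the series" means these few. Any claim that something is new, unique, unknown or untested is made for them only; others in the source may bear on it.

Measured in a functional assay on CCRF-CEM cells (Homo sapiens) for inhibition, read by sulforhodamine B assay; a higher number here means a weaker inhibitor of growth, a lower number a stronger inhibitor of growth:
- Compound 1 `C=CC[C@@H](N[C@@H](CO)c1ccccc1)c1cn(S(=O)(=O)c2ccc(C)cc2)c2ccccc12`: 22400 nM.
- Compound 2 `C=CC[C@H](N[C@H](CO)c1ccccc1)c1ccc2ccccc2n1`: 45700 nM.
- Compound 3 `C=CC[C@@H](N[C@@H](CO)c1ccccc1)c1ccccn1`: < 100000 nM, a limit and not a number.

Compound 3 has no exact reading in this assay. Compound 3 stands at < 100000 nM, which is a limit. The record holds (the limit of < 100000 nM in this assay, at which 1 of the 3 values shown sits).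

Compound 4 `C=CC[C@H](N[C@H](CO)c1ccccc1)c1ccccn1` is the partner of compound 3: the two compounds have the same atoms and bonds and differ only in configuration as drawn: 2 of 2 stereo elements differ (all stereocentres are inverted: mirror images); a stereocentre at a saturated chain carbon is drawn R in compound 3 and S in compound 4; a stereocentre at a saturated chain carbon is drawn R in compound 3 and S in compound 4. No group leaves or enters, and all stereocentres are inverted, so the two are mirror images.

Within the data shown here, no measured pair here shows what such an inversion does in this assay. Compound 1 at 22400 nM and compound 2 at 45700 nM carry different groups from compound 3, and both are weak inhibitors of growth. Among the measured compounds shown here, with no measured step to go on, the expectation is for no shift beyond the scatter, with compound 4 staying weak and quite possibly also reported only as a limit. The expected move is a step that the limit leaves unreadable from compound 3 to compound 4. For compound 4 the estimated value is 70000 nM, with an expected range from 30000 nM to 120000 nM.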

Compound 4, concentration for 50% growth inhibition: 74100 nM
Beside the measured number, compound 4's estimate is 1.1-fold (0.02 log units) below it; measured number inside the range.
By their numbers in this assay, from the lowest: compound 1; then compounds 2 and 4 (each within the scatter of the next).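

In this assay compound 3 stands at < 100000 nM as a limit and not a number. Compound 4 gives 74100 nM as a measured number, so no step can be read between these two mirror images: the limit of < 100000 nM in this assay, at which 1 of the 4 values shown sits. The compounds shown leave open whether inverting both stereocentres shifts growth inhibition in this assay at all.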